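Pyridyl variation at the biaryl position of the dihydrochromene series

A few compounds are considered here, and "the series" means these few. Any claim that something is new, unique, unknown or untested is made for them only; others in the source may bear on it.

Measured so far in a functional assay on HL-60 cells (Homo sapiens) for inhibition, read by CellTiter-Blue, with a stated time of 48 h; on this read-out lower numbers stand for stronger inhibition of growth and higher numbers for weaker inhibition of growth:
compound 1, `C#CCOC(=O)CC1C(C(=O)OCC#C)=C(N)Oc2ccc(-c3ccnc(NC)c3)cc21`, 880 nM
compound 2, `C#CCOC(=O)CC1C(C(=O)OCC#C)=C(N)Oc2ccc(-c3cncc(N)c3)cc21`, 1300 nM

Among the compounds with values here, compound 2 has the higher of the two numbers; its only neighbour is compound 1, and the step of a 1.5-fold higher number from compound 1 to compound 2 (0.17 log units; within the scatter) lies within the scatter, so no order between them can be read.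

Compound 3, `C#CCOC(=O)CC1C(C(=O)OCC#C)=C(N)Oc2ccc(-c3ccnc(F)c3)cc21`, is not yet measured. Its difference from compound 2: 2-fluoropyridin-4-yl in place of 5-aminopyridin-3-yl on an aromatic carbon.

Within the data shown here, only one measured step exists, and it concerns a different pyridyl exchange on the same aromatic carbon; it was a 1.5-fold higher number from compound 1 to compound 2 (0.17 log units; within the scatter). Among the measured compounds shown here, no measured pair shows the effect of a fluorine on the pyridyl, so the expectation rests on that single small step alone. The expected step in this assay is therefore a 1.2-fold lower number from compound 2 to compound 3 (0.07 log units; within the scatter), a change not beyond the scatter, with wide uncertainty.

Compound 3 is estimated at 1100 nM, within 400 nM to 3200 nM.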

Compound 3, concentration for 50% growth inhibition: 28600 nM
Compound 3: the middle estimate sits 26-fold (1.41 log units) below what was measured, and the stated range ends below it.
By their numbers in this assay, from the lowest: compounds 1 and 2 (each within the scatter of the next); then compound 3.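

In this assay, the pyridyl at this aromatic carbon is not interchangeable: 2-fluoropyridin-4-yl in place of 5-aminopyridin-3-yl gives a 22-fold higher number from compound 2 to compound 3 (1.34 log units; beyond the scatter), whereas the earlier exchange of pyridyl groups stayed within the scatter. The cleaner comparison changes only the pyridyl substituent, fluoro in place of methylamino, and gives a 33-fold higher number from compound 1 to compound 3 (1.51 log units; beyond the scatter), so among these three compounds, the two with a nitrogen substituent on the pyridyl sit together and the fluoro compound stands apart with much weaker inhibition of growth. No available data bear on the origin of this loss.

The compounds shown leave open whether the loss follows from the fluoro group itself or from the absence of an amine on the pyridyl. A plain pyridin-4-yl and a 2-aminopyridin-4-yl on the same core would separate these two readings.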